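Swapping Isobutyl for Cyclopropyl at an Ester Oxygen

The compounds below may be only part of what the source reports. "The series", "measured", "known", "first", "only" and "open" are said of these compounds alone.

Three compounds share one core and differ only in the group sitting on an oxygen next to a carbonyl group. Compound 1 `CCCCc1nc(C(C)C)c(CC(=O)OCC(F)(F)F)c(=O)n1Cc1ccc(-c2ccccc2-c2noc(=O)[nH]2)cc1` has no reported result in an ADME assay on microsomes from liver (Mus musculus) for metabolic stability, with a stated time of 30 min; a lower number here means that less of the compound is left, a higher number that more of the compound is left ("not determined" (no result reported)). Compound 2 `CCCCc1nc(C(C)C)c(CC(=O)OCCC)c(=O)n1Cc1ccc(-c2ccccc2-c2noc(=O)[nH]2)cc1` gives 12.6% in this assay. Compound 3 `CCCCc1nc(C(C)C)c(CC(=O)OCC(C)C)c(=O)n1Cc1ccc(-c2ccccc2-c2noc(=O)[nH]2)cc1` gives 13.7% in this assay. Among the measured compounds shown here, the one measured step, a number 1.1 percentage points higher from compound 2 to compound 3 (within the scatter), lies within the scatter, so compound 3 stands at the higher of the two reported numbers without any real separation from compound 2.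

Compound 4 `CCCCc1nc(C(C)C)c(CC(=O)OC2CC2)c(=O)n1Cc1ccc(-c2ccccc2-c2noc(=O)[nH]2)cc1` carries the change (cyclopropyl in place of isobutyl on an oxygen next to a carbonyl group). For the measured compounds named here, the only step that bears on this position, a number 1.1 percentage points higher from compound 2 to compound 3 (within the scatter), was a small change on the same oxygen and produced no movement beyond the scatter. A step of similar kind is therefore expected here, with no shift beyond the scatter in either direction, so the expected step is a number 0.3 percentage points higher from compound 3 to compound 4 (within the scatter). For compound 4 the estimate in this assay is 14%, with a range from 5% to 28%.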

Compound 4, percent of the compound remaining: 11.4%
Compound 4: the middle estimate sits 2.6 percentage points above what was measured; the range from low to high includes it.
By their numbers in this assay, from the lowest: compounds 4, 2 and 3 (each within the scatter of the next).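

In this assay, cyclopropyl in place of isobutyl gives a number 2.3 percentage points lower from compound 3 to compound 4 (within the scatter), and cyclopropyl in place of propyl gives a number 1.2 percentage points lower from compound 2 to compound 4 (within the scatter). The earlier measured step compared only two open chains on this oxygen, whereas these steps show that a three-membered non-aromatic ring of carbon there also stays within the scatter of both chains, so propyl, isobutyl and cyclopropyl cannot be told apart in this read-out. No measurement shown here offers an explanation for this result.

Going by these compounds, what remains open is whether any group on this oxygen can move the number beyond the scatter, for example a longer chain, or a chain ending in an amine or a carboxylic acid. On these data alone, all of these comparisons also share one core, so whether the same holds on a different core remains open too.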